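The source may hold more compounds than are shown below. What is called first, only, known or untested is meant among the compounds shown, and "the series" means these compounds.

Compound 1 `O=c1[nH]cnc2c1c(-c1ccco1)cn2[C@@H]1O[C@H](CO)[C@@H](O)[C@H]1O` gives 2200 nM in a functional assay on HL-60 cells (Homo sapiens) for antiproliferative activity, read by XTT assay, with a stated time of 72 h; on this read-out higher numbers stand for weaker inhibition and lower numbers for stronger inhibition.
Compound 2 `O=c1[nH]cnc2c1c(-c1cc3ccccc3o1)cn2[C@@H]1O[C@H](CO)[C@@H](O)[C@H]1O` gives > 20000 nM in this assay, a limit of the assay.
Compound 3 `Nc1nc(N)c2c(-c3cc4ccccc4o3)cn([C@@H]3O[C@H](CO)[C@@H](O)[C@H]3O)c2n1` gives > 15000 nM in this assay, again a limit of the assay.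

Compound 4 `Nc1nc(N)c2c(-c3ccco3)cn([C@@H]3O[C@H](CO)[C@@H](O)[C@H]3O)c2n1` is not yet measured. The change from compound 3 to compound 4 is furan-2-yl in place of 1-benzofuran-2-yl on an aromatic carbon. The same change, from compound 2 to compound 1, is furan-2-yl in place of 1-benzofuran-2-yl on an aromatic carbon; there it brought an at least 9.0-fold lower number from compound 2 to compound 1 (0.95 log units; beyond the scatter), with the number for compound 2 sitting at the limit of > 20000 nM in this assay, at which 1 of the 3 values shown sits. How the core of compound 3 differs from the core of compound 2 is not broken down here. The number for compound 3 sits at the limit of > 15000 nM in this assay, at which 1 of the 3 values shown sits. Compound 4 is expected to show a step of about an at least 5.0-fold lower number from compound 3 to compound 4 (0.69 log units; beyond the scatter) in this assay, resting on an at least 9.0-fold lower number from compound 2 to compound 1 (0.95 log units; beyond the scatter). Compound 4 is accordingly estimated at 3000 nM in this assay, between 800 nM and 15000 nM.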

Compound 4, half-maximal inhibitory concentration: > 20000 nM
Compound 4 gave a limit, no number; the forecaster's own chance of this, stated with the estimate: 25%; middle value at least 6.6-fold (0.82 log units) from the limit.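

Compound 3 and compound 4 both stand at limits of this assay, so the step between them cannot be read. Going by these compounds, whether furan-2-yl in place of 1-benzofuran-2-yl lowers the number on the core of compound 3, as it did from compound 2 to compound 1, stays open.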